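This account rests on a few compounds, and the source may have more. Where it says the series, first, only, none or still open, it means among the compounds named here.

Working notes on the amide chain of the series. In a functional assay on Huh-7 cells (Homo sapiens) for antiproliferative activity, read by CCK-8 assay, with a stated time of 72 h (a lower number here means a stronger inhibitor of growth, a higher number a weaker inhibitor of growth), compound 1 (`CCC1C(=O)N(C)c2cnc(-n3ccc4cc(C(=O)NC(C)C)ccc43)nc2N1c1ccn(C)n1`) gives 6740 nM and compound 2 (`CCCNC(=O)c1ccc2c(ccn2-c2ncc3c(n2)N(c2ccn(C)n2)C(CC)C(=O)N3C)c1`) gives 7280 nM on the same read-out. For the measured compounds named here, compound 2 therefore stands level with compound 1, the only other number so far (a 1.1-fold higher number from compound 1 to compound 2 (0.03 log units; within the scatter)).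

The next compound is compound 3 (`CCNC(=O)c1ccc2c(ccn2-c2ncc3c(n2)N(c2ccn(C)n2)C(CC)C(=O)N3C)c1`). Its change from compound 2 is hydrogen in place of methyl on a saturated chain carbon, two bonds along the chain from an amide-type nitrogen in full: hydrogen in place of methyl on a saturated chain carbon, two bonds along the chain from an amide-type nitrogen, which turns propyl to ethyl.

Going by the values given here, only one measured step bears on this, the swap of isopropyl for propyl on that same nitrogen (a 1.1-fold higher number from compound 1 to compound 2 (0.03 log units; within the scatter)). It did not move the number beyond the scatter, but it is a single pair, and no chain shorter than that of compound 2 has been measured. On these data alone, no step beyond the scatter is therefore expected in this assay, and the direction stays open. The estimated change is small (a 1.0-fold lower number from compound 2 to compound 3 (0.02 log units; within the scatter)). For compound 3 the expected value is 7000 nM, with an estimated range from 3500 nM to 14000 nM.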

Compound 3, concentration for 50% growth inhibition: 20300 nM
Compound 3: middle estimate off by 2.9-fold (0.46 log units), on the low side, and the stated range ends below it.
By their numbers in this assay, from the lowest: compounds 1 and 2 (each within the scatter of the next); then compound 3.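

In this assay, for the compounds shown here, this is the first change on the amide chain to go beyond the scatter: cutting propyl to ethyl gives (a 2.8-fold higher number from compound 2 to compound 3 (0.45 log units; beyond the scatter)), whereas the swap of isopropyl for propyl on the same nitrogen gives only (a 1.1-fold higher number from compound 1 to compound 2 (0.03 log units; within the scatter)). The branched chain shows the same gap to ethyl (a 3.0-fold higher number from compound 1 to compound 3 (0.48 log units; beyond the scatter)), so among these three compounds the position tolerates a change in chain shape between isopropyl and propyl, while the shorter ethyl chain gives the weaker inhibitor of growth, though the step is modest. Nothing available on these compounds accounts for the step.

The compounds shown leave open whether the number keeps rising as the chain shortens further, to a methyl on that nitrogen or to the plain amide with only hydrogen there, and whether a longer chain such as butyl would stay level with propyl or give a lower number. They also leave open how a chain ending in an amine or a carboxylic acid would read at this position, and whether the ethyl step holds when the rest of the core changes.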